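Swapping the group on the amide-type nitrogen of a shared core

A few compounds are considered here, and "the series" means these few. Any claim that something is new, unique, unknown or untested is made for them only; others in the source may bear on it.

Three amides built on one shared core have been measured in a functional assay on PC-3 cells (Homo sapiens) for antiproliferative activity, read by MTT assay, with a stated time of 24 h; on this read-out higher numbers stand for weaker inhibition and lower numbers for stronger inhibition. There, compound 1 `CCn1c(C(=O)N[C@@H](CC(=O)OC)C(=O)OC)ccc1C(CC)(CC)c1ccc(OCS(=O)(=O)c2ccccc2)c(C)c1` gives 6490 nM, compound 2 `CCn1c(C(=O)NCCN)ccc1C(CC)(CC)c1ccc(OCS(=O)(=O)c2ccccc2)c(C)c1` gives 6890 nM and compound 3 `CCn1c(C(=O)N[C@@H](CO)CCO)ccc1C(CC)(CC)c1ccc(OCS(=O)(=O)c2ccccc2)c(C)c1` gives 14100 nM. Compound 3 therefore has the highest number of the three and is the weakest inhibitor in the set.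

Compound 4 `CCn1c(C(=O)N[C@@H](C(=O)O)C(C)C)ccc1C(CC)(CC)c1ccc(OCS(=O)(=O)c2ccccc2)c(C)c1` keeps the core of compound 3 and alters only the group on the amide-type nitrogen, with 1-carboxy-2-methylpropyl in place of 3-hydroxy-1-(hydroxymethyl)propyl on an amide-type nitrogen. All three measured steps changed this same group. The first, a 1.1-fold higher number from compound 1 to compound 2 (0.03 log units; within the scatter), stayed within the scatter, while a 2.2-fold higher number from compound 1 to compound 3 (0.34 log units; beyond the scatter) and a 2.0-fold higher number from compound 2 to compound 3 (0.31 log units; beyond the scatter) were modest. Among the compounds with values here, no measured compound carries the entering group, so these steps offer only a general guide to its effect.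

On that evidence, a large step in this assay seems unlikely, and none clearly beyond the scatter is expected. Any movement is expected to be slightly downward, since compound 3 gives the top number at 14100 nM. The expected change is a 1.4-fold lower number from compound 3 to compound 4 (0.15 log units; within the scatter). For compound 4 the estimated value is 10000 nM, within an expected range of 4500 nM to 22000 nM.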

Compound 4, half-maximal inhibitory concentration: 3070 nM
The estimate for compound 4 lay 3.3-fold (0.51 log units) above the measured number; measured number outside the range, below it.
By their numbers in this assay, from the lowest: compound 4; then compounds 1 and 2 (each within the scatter of the next); then compound 3.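

In this assay, the group on the amide-type nitrogen moved the number further than the earlier compounds had shown: 1-carboxy-2-methylpropyl in place of 3-hydroxy-1-(hydroxymethyl)propyl gives a 4.6-fold lower number from compound 3 to compound 4 (0.66 log units; beyond the scatter) and is the largest step at this position so far. The entering group also separates compound 4 from the two compounds that had sat within the scatter of each other, with a 2.2-fold lower number from compound 2 to compound 4 (0.35 log units; beyond the scatter) and a 2.1-fold lower number from compound 1 to compound 4 (0.33 log units; beyond the scatter), which makes compound 4 the strongest inhibitor of the four. Nothing in the available data explains why this group gives the lowest number.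

The compounds shown leave open whether the shift follows the carboxylic acid or the branched carbon chain of 1-carboxy-2-methylpropyl, since compound 4 alone carries both. A methyl ester of the same group, a plain 2-methylpropyl group on that nitrogen, or a carboxylic acid on a longer unbranched chain would be needed to tell these two parts apart.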